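Dropping a Methoxy Group from a Coumarin-Linked Dienone

The source may report more compounds than this note shows. Statements on the series, on what has been measured and on what is new or still open speak of the compounds shown alone.

This study concerns three compounds measured in a functional assay on HCT-116 cells (Homo sapiens) for inhibition, read by sulforhodamine B assay, with a stated time of 48 h, tested at 50 uM (on this read-out lower numbers stand for less inhibition of growth and higher numbers for more inhibition of growth at the one concentration tested), and one that awaits measurement there. Compound 1, with the structure `COc1cc(/C=C/C(=O)/C=C/c2cc(OC)c(OC)c(OC)c2)ccc1OCc1cn(CCCOc2cc(=O)oc3ccccc23)nn1`, gives 76%. Compound 2, with the structure `COc1ccc(/C=C/C(=O)/C=C/c2ccc(OCc3cn(CCOc4cc(=O)oc5ccccc45)nn3)c(OC)c2)cc1`, gives 71%. Compound 3, with the structure `COc1cc(/C=C/C(=O)/C=C/c2cccc3ccccc23)ccc1OCc1cn(CCCCCOc2cc(=O)oc3ccccc23)nn1`, gives 42%. Among these three numbers compound 2 stands second highest; its nearest neighbour is compound 1, a number five points higher and within the usual scatter, while the furthest is compound 3, a lower number whose distance from compound 2 lies beyond the scatter. So compound 2 and compound 1 cannot be told apart on this read-out, whereas compound 3 clearly inhibits growth less.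

The step now followed goes from compound 2 to compound 4, whose structure is `COc1cc(/C=C/C(=O)/C=C/c2ccccc2)ccc1OCc1cn(CCOc2cc(=O)oc3ccccc23)nn1`. The change is hydrogen in place of methoxy on an aromatic carbon, para to a large group.

Going by the values given here, no measured pair shows this exact change, so the size of the step is not known from direct comparison. The shared core and the coumarin-bearing chain stay the same, and the expected step from compound 2 to compound 4 is estimated to be small, a number 9 percentage points lower from compound 2 to compound 4 (within the scatter), leaning slightly toward less growth inhibition but likely within the scatter. Compound 4 is therefore expected to give about 62%, with a range from 44% to 78%.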

Compound 4, percent growth inhibition at one concentration: 56%
Compound 4: middle estimate off by 6 percentage points, on the high side; low and high end bracket the measured number.
By their numbers in this assay, from the lowest: compound 3; then compound 4; then compounds 2 and 1 (each within the scatter of the next).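

In this assay, going by these compounds alone, hydrogen in place of methoxy on an aromatic carbon gives a number 15 percentage points lower from compound 2 to compound 4 (beyond the scatter), the only step in this set between two compounds that differ in one place. The earlier compounds shown here differ in several places at once, so they could not show that this position, para to a large group, responds to what it carries: on this pair, the 4-methoxyphenyl end goes with more growth inhibition than the phenyl end, although the step is modest and rests on a single pair. No supporting measurement here bears on why the number falls.

The compounds shown leave open whether the methoxy group is special or whether another group on this carbon, such as a hydroxyl, a fluorine or an amine, would serve as well or better. They also leave open whether the step would keep its size with a longer linking chain, or at concentrations other than the one tested.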